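A few compounds are considered here, and "the series" means these few. Any claim that something is new, unique, unknown or untested is made for them only; others in the source may bear on it.

Measured so far in a functional assay on K562 cells (Homo sapiens) for antiproliferative activity, read by MTT assay, with a stated time of 72 h; on this read-out lower numbers stand for stronger inhibition and higher numbers for weaker inhibition:

Compound 1 `COc1cc(-n2ncnc2-c2cccc([N+](=O)[O-])c2)cc(OC)c1OC`: > 10000 nM, which is a limit of this assay rather than a number.
Compound 2 `COc1cc(-c2ncnn2-c2ccc(Cl)c(Cl)c2)cc(OC)c1OC`: > 10000 nM, again a limit of this assay.
Compound 3 `COc1cc(-c2ncnn2-c2ccc(Cl)cc2Cl)cc(OC)c1OC`: > 10000 nM, again a limit of this assay.

Among the measured compounds shown here, compound 1 therefore stands at the same limit as every other compound measured so far, as summed up by the limit of > 10000 nM in this assay, at which 3 of the 3 values shown sit. For the measured compounds named here, no compound measured here has a readable number, and the one change between measured compounds, 2,4-dichlorophenyl in place of 3,4-dichlorophenyl on an aromatic nitrogen, gives a step that the two limits leave unreadable from compound 2 to compound 3, so no size can be drawn from it.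

Compound 4 `COc1cc(-n2ncnc2-c2cccc(F)c2)cc(OC)c1OC` differs from compound 1 by fluoro in place of nitro on an aromatic carbon. Going by the values given here, no measured step bears on this particular change, so nothing about its size or direction can be read from the measured compounds. With every measured value sitting at the limit, the expected step from compound 1 to compound 4 in this assay is a step that the limit leaves unreadable from compound 1 to compound 4, with the outcome most likely to be another limit. Compound 4 is therefore estimated at 20000 nM, within a range from 5000 nM to 80000 nM.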

Compound 4, half-maximal inhibitory concentration: > 10000 nM
Compound 4 was reported as a limit (the forecaster's own chance of this, stated with the estimate: 70%); the middle value lies beyond the limit too.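

Compound 1 and compound 4 both stand at a limit rather than a number, so no step can be read between them: the limit of > 10000 nM in this assay, at which 4 of the 4 values shown sit.

The compounds shown leave open how strongly any of them inhibits, and whether any change to the shared core gives a readable number in this assay.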